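The compounds below may be only part of what the source reports. "The series", "measured", "known", "first", "only" and "open" are said of these compounds alone.

Compounds measured so far, each in a functional assay on ASPC1 cells (Homo sapiens) for antiproliferative activity, read by sulforhodamine B assay, with a stated time of 48 h; a lower number here means a stronger inhibitor, a higher number a weaker inhibitor:
- compound 1, `O=C(CCCCCCN1C(=O)/C(=N\O)c2cc(Cl)ccc21)NO`, gives 1860 nM
- compound 2, `O=C(CCCCCCN1C(=O)/C(=N\O)c2cc(Br)ccc21)NO`, gives 80 nM
- compound 3, `CO/N=C1/C(=O)N(CCCCCCC(=O)NO)c2ccc(Cl)cc21`, gives 490 nM

Compound 4, `CO/N=C1/C(=O)N(CCCCCCC(=O)NO)c2ccc(Br)cc21`, is not yet measured in this assay. It is reached from compound 3 by one change, (bromo in place of chloro on an aromatic carbon). The same change, (bromo in place of chloro on an aromatic carbon), is already known from one pair: in this assay it made a step of a 23-fold lower number from compound 1 to compound 2 (1.37 log units; beyond the scatter). The place of the change is described in the same words for both pairs, so the change is the same, set on two different cores. How the core of compound 3 differs from the core of compound 1 is not broken down here.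

Compound 3 stands between compound 1 and compound 2 in this assay, and the difference between its number and that of compound 1 is beyond the scatter. Going by the values given here, for compound 4, a step of an 8.2-fold lower number from compound 3 to compound 4 (0.91 log units; beyond the scatter) is expected, because the only earlier example of this change gave a 23-fold lower number from compound 1 to compound 2 (1.37 log units; beyond the scatter) in this assay. With a single precedent on another core, the expected step is taken somewhat smaller than that one. Compound 4 is therefore estimated at 60 nM, within a range of 20 nM to 300 nM.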

Compound 4, half-maximal inhibitory concentration: 1680 nM
Compound 4: middle estimate off by 28-fold (1.45 log units), on the low side; measured number outside the range, above it.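

In this assay, putting bromo in place of chloro on the aromatic carbon gave a 3.4-fold higher number from compound 3 to compound 4 (0.54 log units; beyond the scatter), so on this core the bromo compound is the weaker inhibitor. Set beside the earlier pair, the same change moved the number in opposite directions on the two cores, and the gap between the two steps is real rather than scatter: the same change on two cores in this assay, a 23-fold lower number (1.37 log units; beyond the scatter) from compound 1 to compound 2 and a 3.4-fold higher number (0.54 log units; beyond the scatter) from compound 3 to compound 4, 80-fold (1.90 log units) apart, beyond the scatter of two such steps

The effect of this change therefore did not carry from the core of compound 1 to the core of compound 3, in either size or direction, although two pairs cannot show which difference between the cores is responsible or predict the outcome on a third core. The compounds shown leave open how a fluoro or iodo group on the same aromatic carbon would behave on each core. They also leave open whether the split between the two cores would persist with a shorter or longer chain.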